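Sulfanyl-linked ring variation on the diaryl imidazole series

The compounds below may be only part of what the source reports. "The series", "measured", "known", "first", "only" and "open" are said of these compounds alone.

Measured so far:
compound 1 `c1ccc(-c2nc(SCC3CCCCO3)[nH]c2-c2ccccc2)cc1` — 210 nM
compound 2 `c1ccc(-c2nc(SCC3OCCO3)[nH]c2-c2ccccc2)cc1` — 530 nM

Within the data shown here, compound 2 stands at the higher of the two numbers in an assay on microsomes from liver for inhibition of sterol O-acyltransferase 1 (Rattus norvegicus); a higher number here means a weaker inhibitor, a lower number a stronger inhibitor; the only neighbour is compound 1, and the step of a 2.5-fold higher number from compound 1 to compound 2 (0.40 log units; beyond the scatter) lies beyond the scatter. Compound 3 `c1ccc(-c2nc(SCC3CCCCC3)[nH]c2-c2ccccc2)cc1` is not yet measured. It differs from compound 2 by cyclohexyl in place of 1,3-dioxolan-2-yl on a saturated chain carbon bound to a sulfur, that is, a six-membered non-aromatic ring of carbon only enters where the five-membered ring with two oxygens leaves.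

Among the measured compounds shown here, the one measured step that bears on this change is a 2.5-fold higher number from compound 1 to compound 2 (0.40 log units; beyond the scatter), where the oxan-2-yl ring, also six-membered, gave the lower number. Compound 3 is therefore expected to move back in that direction, with a step of about a 3.5-fold lower number from compound 2 to compound 3 (0.55 log units; beyond the scatter). On that basis compound 3 is estimated at 150 nM in this assay, within a range of 50 nM to 500 nM.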

Compound 3, half-maximal inhibitory concentration: 100 nM
The estimate for compound 3 lay 1.5-fold (0.18 log units) above the measured number; the range from low to high includes it.
By their numbers in this assay, from the lowest: compound 3; then compound 1; then compound 2.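

Compound 3, with cyclohexyl on a saturated chain carbon bound to a sulfur, gives the lowest number of the three in this assay, with a 5.3-fold lower number from compound 2 to compound 3 (0.72 log units; beyond the scatter) and a 2.1-fold lower number from compound 1 to compound 3 (0.32 log units; beyond the scatter) as the two steps, both beyond the scatter. Among these compounds, then, a ring oxygen is not needed at this position for the lowest number. Compound 1 and compound 3 both carry a six-membered ring and still stand apart beyond the scatter, so ring size alone does not set the number here.

From the compounds shown here alone, whether a piperidine ring, a phenyl ring or an open hexyl chain at the same place would keep or lower the number remains open. Nothing available explains the order of the three rings.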